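From Phenyl to 2-Fluorophenyl in Compound 1

The compounds below may be only part of what the source reports. "The series", "measured", "known", "first", "only" and "open" are said of these compounds alone.

In a functional assay on MDA-MB-436 cells (Homo sapiens) for antiproliferative activity, read by MTT assay, with a stated time of 24 h (on this read-out lower numbers stand for stronger inhibition and higher numbers for weaker inhibition), compound 1 `O=C(O)CC(NC(=O)c1ccc(Cl)cc1Cl)c1ccccc1` gives 78200 nM and compound 3 `CC(C)(C)c1ccc(C(CC(=O)O)NS(=O)(=O)c2ccc(F)cc2)cc1` gives 68900 nM, two values that lie within the usual scatter of each other. Compound 2 `CC(C)(C)c1ccc(C(CC(=O)O)NC(=O)c2ccc(Cl)cc2Cl)cc1` reads > 100000 nM, which is a limit of the assay and not a number. Going by the values given here, compound 1 therefore sits with compound 3 among the only two true numbers available, and both are large numbers on a scale where lower means stronger inhibition.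

Compound 4 `O=C(O)CC(NC(=O)c1ccc(Cl)cc1Cl)c1ccccc1F` differs from compound 1 by one small edit, fluoro in place of hydrogen on an aromatic carbon, turning phenyl into 2-fluorophenyl. Among the compounds with values here, only one measured step offers a comparison, an at least 1.2-fold higher number from compound 1 to compound 2 (0.10 log units; that floor lies within the scatter), where tert-butyl replaces hydrogen on an aromatic carbon. As far as these compounds go, its full size stays unknown because of the limit of > 100000 nM in this assay, at which 1 of the 3 values shown sits. That step involves a different group, so it is only a loose guide, and its floor does not clear the scatter. No step beyond the scatter is therefore expected for the fluoro change. The estimated step is a 1.1-fold lower number from compound 1 to compound 4 (0.05 log units; within the scatter), with no clear direction expected. For compound 4 the expected value is 70000 nM, within an estimated range of 30000 nM to 100000 nM.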

Compound 4, half-maximal inhibitory concentration: > 100000 nM
Compound 4: a limit, no number; the forecaster's own chance of this, stated with the estimate: 25%; middle value at least 1.4-fold (0.15 log units) away from the limit.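

In this assay compound 4 gives > 100000 nM, which is a limit of the assay and not a number. The step reads an at least 1.2-fold higher number from compound 1 to compound 4 (0.10 log units; that floor lies within the scatter), so fluoro in place of hydrogen on this aromatic carbon, ortho to a large group, brings no sign of stronger inhibition, although the floor of the step is too small to show that the change weakens it. The new point is that even fluoro, with its 1 heavy atom, leaves compound 4 at the same limit as compound 2, which carries the much larger tert-butyl, and this limit now covers more of the compounds shown: the limit of > 100000 nM in this assay, at which 2 of the 4 values shown sit.

The true size of the step therefore stays unknown, and the compounds shown cannot tell whether the fluoro change matters beyond the usual scatter or hardly at all. Also open, as far as these compounds go, is whether a different group at this same place, such as an amine or a methoxy group, would give a number clearly lower than that of compound 1.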